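Swapping the Chain-End Ring in an Oxazole Ketone Series

A few compounds are considered here, and "the series" means these few. Any claim that something is new, unique, unknown or untested is made for them only; others in the source may bear on it.

Measured so far:
- compound 1, `O=C(CCCCC#Cc1ccccn1)c1ncc(-c2ccccn2)o1`: 280 nM
- compound 2, `O=C(CCCCCCc1cccc2ccccc12)c1ncc(-c2ccccn2)o1`: 2.6 nM
- compound 3, `O=C(CCCCCCc1ccccn1)c1ncc(-c2ccccn2)o1`: 120 nM

All three share one core and differ only in the chain that hangs from the carbonyl and in the group at its end. In an assay for inhibition of Fatty-acid amide hydrolase 1 (Rattus norvegicus) (a higher number here means a weaker inhibitor, a lower number a stronger inhibitor), compound 3 gives 120 nM, the second highest of the three numbers. For the measured compounds named here, its nearest neighbour is compound 1, which gives 280 nM; the only directly comparable step, a 2.3-fold lower number from compound 1 to compound 3 (0.37 log units; beyond the scatter), is modest. Compound 2 gives 2.6 nM, far below both.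

Compound 4, `CSc1cccc(CCCCCCC(=O)c2ncc(-c3ccccn3)o2)c1`, is not yet measured. It differs from compound 3 in one place: 3-(methylsulfanyl)phenyl in place of pyridin-2-yl on a saturated chain carbon, six bonds along the chain from a carbonyl carbon. The step from compound 1 to compound 3 changed the chain, not the ring at its end, so it speaks only indirectly to this change. Going by the values given here, compound 2 shows that a different end group on the same saturated chain can sit far below compound 3, but no step between compound 2 and compound 3 has been worked out here.

For compound 4 the number is therefore expected to fall, by roughly a 10-fold lower number from compound 3 to compound 4 (1.00 log units; beyond the scatter), in this assay. The estimate for compound 4 is 12 nM, with a range from 3 nM to 50 nM.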

Compound 4, inhibition constant: 4.2 nM
Compound 4: middle estimate off by 2.9-fold (0.46 log units), on the high side, within the range that was stated.
By their numbers in this assay, from the lowest: compounds 2 and 4 (each within the scatter of the next); then compound 3; then compound 1.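

In this assay, the change at the chain end, on a saturated chain carbon, six bonds along the chain from a carbonyl carbon, gives a 29-fold lower number from compound 3 to compound 4 (1.46 log units; beyond the scatter), a large step set against the modest 2.3-fold lower number from compound 1 to compound 3 (0.37 log units; beyond the scatter) that came from altering the chain. With the chain and the shared core held constant, this shows that the end group alone can move the number substantially, and that compound 2 at 2.6 nM is not alone at the low end, since compound 4 at 4.2 nM lies within the scatter of it. No measurement shown here explains why the new end group gives so much lower a number.

Still open, as far as these compounds go, is how much of the step belongs to the ring of carbon only and how much to the methylsulfanyl group, since the two arrive together and an unsubstituted phenyl at the same place would separate them. Also open, from the compounds shown here alone, is whether a methoxy group could stand in for methylsulfanyl, and whether the step would hold on the triple-bonded chain of compound 1.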